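Homologating the Side Chain of Compound 2

The source may report more compounds than this note shows. Statements on the series, on what has been measured and on what is new or still open speak of the compounds shown alone.

Compound 1, `O=C1NN(c2ccccc2)CC1Cc1cccs1`: in an assay on isolated protein for inhibition of Polyunsaturated fatty acid 5-lipoxygenase (Rattus norvegicus) (a higher number here means a weaker inhibitor, a lower number a stronger inhibitor), compound 1 gives 140 nM.
Compound 2, `COCc1cn(-c2ccccc2)[nH]c1=O`: in this assay compound 2 gives only > 1000 nM, which is a limit of the assay and not a number.

For the measured compounds named here, compound 2 therefore sits at the limit of > 1000 nM in this assay, at which 1 of the 2 values shown sits, and no measured step connects it to compound 1. Compound 3, `COCCc1cn(-c2ccccc2)[nH]c1=O`, differs from compound 2 by methoxymethyl in place of methoxy on a saturated chain carbon bound to an aromatic carbon. Nothing measured here shows what this change does in this assay, so no step beyond the usual scatter is expected in either direction. For compound 3 the estimate in this assay is 2000 nM, expected to fall between 700 nM and 6000 nM. This estimate corresponds to an expected step that the limit leaves unreadable from compound 2 to compound 3.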

Compound 3, half-maximal inhibitory concentration: > 1000 nM
Compound 3: no number, only a limit; the forecaster's own chance of this, stated with the estimate: 70%; the middle value does not contradict the limit.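

No step can be read between compound 2 and compound 3, because both values are limits of the assay and not numbers: the limit of > 1000 nM in this assay, at which 2 of the 3 values shown sit.

As far as these compounds go, whether the methoxymethyl or the 2-methoxyethyl side chain gives the stronger inhibitor stays open.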